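The source may report more compounds than this note shows. Statements on the series, on what has been measured and on what is new or still open speak of the compounds shown alone.

Measured so far in an assay on isolated protein for inhibition of MAP kinase-activated protein kinase 5 (Homo sapiens), read by mobility shift assay, tested at 30 uM; on this read-out lower numbers stand for less inhibition and higher numbers for more inhibition at the one concentration tested (going by the name of the read-out):

compound 1 `Nc1n[nH]c2cc(-c3ccccn3)[nH]c(=O)c12` gives 18%
compound 2 `Cc1cc2c(c(N)nn2C)c(=O)[nH]1` gives 5%
compound 3 `Cn1nc(N)c2c(=O)[nH]c(-c3ccccc3)cc21` gives 11%

Compound 3 sits between the other two on these three numbers, and both gaps are small: compound 2 is the nearer neighbour, the step of a number 6 percentage points higher from compound 2 to compound 3 (within the scatter) lies within the scatter, and compound 1 is the further one, seven points apart, again within the scatter. Among the measured compounds shown here, the one measured step, phenyl in place of methyl, therefore tells of no change that the assay can resolve.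

Compound 4 `Cn1nc(N)c2c(=O)[nH]c(-c3ccccn3)cc21` is reached from compound 3 by a single change: pyridin-2-yl in place of phenyl on an aromatic carbon. For the measured compounds named here, no measured pair shows this exchange of pyridin-2-yl for phenyl on the core of compound 3. Compound 1 does carry a pyridin-2-yl group, but on a core that differs from that of compound 3 in another place, so its value is only a loose hint. The expectation for compound 4 is thus a step of a number 3 percentage points higher from compound 3 to compound 4 (within the scatter) that stays within the scatter. Compound 4 is estimated at 14%, within a range from 4% to 26%.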

Compound 4, a percentage reported as inhibition, at one concentration (the size of the read-out at that concentration, not a potency): 9%
Compound 4: the middle estimate sits 5 percentage points above what was measured, and the stated range covers the measured number.
By their numbers in this assay, from the lowest: compounds 2, 4, 3 and 1 (each within the scatter of the next, the first and the last beyond it).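

In this assay, among the compounds shown here, the swap of phenyl for pyridin-2-yl on the aromatic carbon next to the ring nitrogen gives a number 2 percentage points lower from compound 3 to compound 4 (within the scatter) and so brings in a ring nitrogen and a hydrogen-bond acceptor with no step that this read-out can resolve. Pyridin-2-yl in place of methyl gives a number 4 percentage points higher from compound 2 to compound 4 (within the scatter) and methyl in place of hydrogen on an aromatic nitrogen gives a number 9 percentage points lower from compound 1 to compound 4 (within the scatter) so neither of these single changes is resolved in this assay either. Nothing available bears on these small steps.

The compounds shown leave open whether a carboxylic acid or an amine in place of pyridin-2-yl at this position would give a step beyond the scatter. On these data alone, it also remains open what a longer chain in place of the methyl on the aromatic nitrogen would do.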